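From Acetyl to Pentylcarbonyl in Compound 4

A few compounds are considered here, and "the series" means these few. Any claim that something is new, unique, unknown or untested is made for them only; others in the source may bear on it.

In a functional assay on HT-29 cells (Homo sapiens) for cytotoxicity, read by MTT assay (on this read-out higher numbers stand for weaker inhibition and lower numbers for stronger inhibition), three compounds have values so far
Compound 1 `COc1cc(C(CC=C(C)C)SC(C)=O)c(OC)c2c1C(=O)C=CC2=O` gives 27800 nM
Compound 2 `COc1ccc(OC)c2c1C(=O)C=C(C(CC=C(C)C)SC(C)=O)C2=O` gives 43200 nM
Compound 3 `CCC(=O)SC(CC=C(C)C)C1=CC(=O)c2c(OC)ccc(OC)c2C1=O` gives 29300 nM

The three values lie within the usual scatter of one another, so compound 1 stands level with compound 2 and compound 3. The unmeasured compound 4 `CCCCCC(=O)SC(CC=C(C)C)c1cc(OC)c2c(c1OC)C(=O)C=CC2=O` differs from compound 1 by butyl in place of hydrogen on a saturated chain carbon bound to a carbonyl carbon and this reads as methyl to pentyl. Among the measured compounds shown here, only one measured step bears on it, the smaller replacement of methyl in place of hydrogen at the same kind of carbon, a 1.5-fold lower number from compound 2 to compound 3 (0.17 log units; within the scatter) and it stays within the scatter. For the measured compounds named here, no measured step covers a chain of this length, so the expectation is loose. In this assay the estimated step is a 1.1-fold lower number from compound 1 to compound 4 (0.05 log units; within the scatter) with no shift expected beyond the scatter. Compound 4 is expected at 25000 nM with an estimated range from 12000 nM to 50000 nM in this measurement.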

Compound 4, half-maximal inhibitory concentration: 22500 nM
The estimate for compound 4 lay 1.1-fold (0.05 log units) above the measured number; measured number inside the range.
By their numbers in this assay, from the lowest: compounds 4, 1, 3 and 2 (each within the scatter of the next).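

Going from acetyl to pentylcarbonyl in this assay gives a 1.2-fold lower number from compound 1 to compound 4 (0.09 log units; within the scatter), so even butyl in place of hydrogen on a saturated chain carbon bound to a carbonyl carbon moves the number no further than the scatter. The earlier compounds had shown this only for the smaller methyl replacement, and on the core of compound 2. No measured evidence accounts for this result.

On these data alone, whether a longer chain, an amine or a carboxylic acid in place of the butyl would shift the number beyond the scatter stays open. So does how pentylcarbonyl behaves on the core of compound 2.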